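The compounds below may be only part of what the source reports. "The series", "measured", "known", "first", "only" and "open" are said of these compounds alone.

Compound 1 `C=CC1=C(C(=O)O)C(c2ccc(F)cc2)OC1` gives, as a limit in a functional assay on SW480 cells (Homo sapiens) for cytotoxicity, read by MTT assay, with a stated time of 24 h (a lower number here means a stronger inhibitor, a higher number a weaker inhibitor), > 100000 nM.
Compound 2 `C=CC1=C(C(=O)O)C(c2ccc(OC)cc2)OC1` gives, as a limit in this assay, > 100000 nM.
Compound 3 `C=CC1=C(C(=O)NCCCCC)C(c2ccc(OC)cc2)OC1` gives, as a limit in this assay, > 100000 nM.

Compound 2 therefore stands at a limit only, with no number of its own; the same holds for the other two values, because of the limit of > 100000 nM in this assay, at which 3 of the 3 values shown sit. The step that the two limits leave unreadable from compound 1 to compound 2 and the step that the two limits leave unreadable from compound 2 to compound 3 are both unreadable for that reason. Compound 4 `C=CC1=C(C(=O)O)C(c2ccc(OC)c(OC)c2)OC1` differs from compound 2 by methoxy in place of hydrogen on an aromatic carbon. Neither measured step bears readably on this change, so no step beyond the scatter can be expected in this assay, and a further limit is the likeliest outcome. Compound 4 is estimated at 150000 nM, between 40000 nM and 600000 nM, an expected step that the limit leaves unreadable from compound 2 to compound 4.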

Compound 4, half-maximal inhibitory concentration: > 100000 nM
Compound 4 ended at the assay's limit; the forecaster's own chance of this, stated with the estimate: 85%; the middle value does not contradict the limit.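

No step can be read between compound 2 and compound 4, since both stand only at a limit in this assay: the limit of > 100000 nM in this assay, at which 4 of the 4 values shown sit.

The compounds shown leave open whether any of these changes on the shared core alters cytotoxicity in this assay.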